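This account rests on a few compounds, and the source may have more. Where it says the series, first, only, none or still open, it means among the compounds named here.

Measured so far:
Compound 1, `COc1ccc(-c2cc(-c3cc4ccccc4n3C)no2)cc1`, gives only a limit in a functional assay on COLO 320 cells (Homo sapiens) for cytotoxicity, read by WST assay, with a stated time of 72 h; a lower number here means a stronger inhibitor, a higher number a weaker inhibitor: > 100000 nM.
Compound 2, `COc1ccc(-c2cc(-c3c(Cl)c4ccccc4n3C)no2)cc1`, gives 78100 nM in this assay.

Among the compounds with values here, compound 2 thus holds the only number in this assay; the other value shown is a limit. Within the data shown here, the one measured step, an at least 1.2-fold lower number from compound 1 to compound 2 (0.10 log units; that floor lies within the scatter), is a floor that sits within the scatter, so it tells little about size. That compound 1 reads as a limit is described by the limit of > 100000 nM in this assay, at which 1 of the 2 values shown sits.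

Compound 3, `Cn1c(-c2cc(-c3ccc(C(F)(F)F)cc3)on2)c(Cl)c2ccccc21`, differs from compound 2 by trifluoromethyl in place of methoxy on an aromatic carbon. Among the measured compounds shown here, no measured step covers this change, and the only measured step concerns a different position, so there is no basis for expecting a move beyond the scatter in either direction. Compound 3 is therefore expected to land near compound 2, with an estimated step of a 1.3-fold lower number from compound 2 to compound 3 (0.11 log units; within the scatter). The estimate for compound 3 in this assay is 60000 nM, within 15000 nM to 250000 nM.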

Compound 3, half-maximal inhibitory concentration: > 100000 nM
Compound 3: only a limit was reported; the forecaster's own chance of this, stated with the estimate: 35%; at least 1.6-fold (0.22 log units) between middle value and limit.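

Trifluoromethyl in place of methoxy, on an aromatic carbon para to a large group, is the first change shown at this position, and in this assay it gives an at least 1.2-fold higher number from compound 2 to compound 3 (0.10 log units; that floor lies within the scatter). That step is only a floor, so it fixes no size for the change, and compound 3 reads as a limit rather than a number. Compound 2 thus still holds the only number, and the other two compounds read as limits: the limit of > 100000 nM in this assay, at which 2 of the 3 values shown sit.

With methoxy and trifluoromethyl the only groups shown on this aromatic carbon, it stays open whether a hydroxyl group, an amine or a carboxylic acid there would give a number clearly lower than that of compound 2. Also open is whether either step shown is larger than its floor.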